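The source may report more compounds than this note shows. Statements on the series, on what has been measured and on what is new or still open speak of the compounds shown alone.

Compound 1 `COc1ccc(/C=C/C(=O)c2cc3ccc(OCc4cccc(OC)c4)cc3oc2=O)cc1` was run in a functional assay on MOLT-4 cells (Homo sapiens) for cytotoxicity, read by MTT assay, with a stated time of 72 h; a lower number here means a stronger inhibitor, a higher number a weaker inhibitor. Compound 1 gives only a limit there, > 100000 nM, which is the limit of > 100000 nM in this assay, at which 1 of the 3 values shown sits. Two other compounds of the same family did give numbers: compound 2 `COC(=O)c1ccc(/C=C/C(=O)c2cc3ccc(O)cc3oc2=O)cc1` gives 3700 nM in this assay, and compound 3 `COc1cc(/C=C/C(=O)c2cc3cc(O)ccc3oc2=O)cc(OC)c1OC` gives 3900 nM in this assay. Compound 4 `COc1cccc(COc2ccc3cc(C(=O)/C=C/c4ccc(C)cc4)c(=O)oc3c2)c1` has not been measured yet. It differs from compound 1 by methyl in place of methoxy on an aromatic carbon: the methoxy leaves and a methyl enters, on an aromatic carbon of a six-membered aromatic ring of carbon only. Going by the values given here, no measured pair shows this change, and the step in this assay is expected to be small, none beyond the scatter. Compound 4 is therefore estimated at 150000 nM, within 30000 nM to 500000 nM. The expected step is a step that the limit leaves unreadable from compound 1 to compound 4.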

Compound 4, half-maximal inhibitory concentration: > 50000 nM
Compound 4: a limit, no number; the forecaster's own chance of this, stated with the estimate: 75%; the middle value does not contradict the limit.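

Compound 1 and compound 4 each give only a limit, not a number, and the step between them cannot be read. As far as these compounds go, whether methyl in place of methoxy on an aromatic carbon changes the strength at all stays open.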